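Methoxy position shift: compound 2 to compound 3

The source may report more compounds than this note shows. Statements on the series, on what has been measured and on what is new or still open speak of the compounds shown alone.

Compound 2 `COc1ccc(CNCCCNS(=O)(=O)c2cc(C(F)(F)F)cc(C(F)(F)F)c2)cc1` stands level with compound 1 `O=S(=O)(NCCCNCc1ccc(Cl)c(C(F)(F)F)c1)c1cc(C(F)(F)F)cc(C(F)(F)F)c1` on the numbers in hand: in a functional assay on HPAC cells (Homo sapiens) for inhibition, read by MTT assay, with a stated time of 72 h (a lower number here means a stronger inhibitor of growth, a higher number a weaker inhibitor of growth), compound 1 gives 3000 nM and compound 2 gives 3000 nM, with the step of no change at the digits printed from compound 1 to compound 2 (within the scatter) lying within the scatter. Compound 3 `COc1cccc(CNCCCNS(=O)(=O)c2cc(C(F)(F)F)cc(C(F)(F)F)c2)c1` differs from compound 2 by 3-methoxyphenyl in place of 4-methoxyphenyl on a saturated chain carbon bound to an amine nitrogen. Among the measured compounds shown here, no measured step moves a substituent around the same ring. For the measured compounds named here, the single step in hand, no change at the digits printed from compound 1 to compound 2 (within the scatter), swaps whole aryl groups and shows no change beyond the scatter. On that basis compound 3 is expected to show a step of no change at the digits printed from compound 2 to compound 3 (within the scatter) in this assay, nothing beyond the scatter. Compound 3 is estimated at 3000 nM, range 1200 nM to 7500 nM.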

Compound 3, concentration for 50% growth inhibition: 2400 nM
Beside the measured number, compound 3's estimate is 1.3-fold (0.10 log units) above it, and the stated range covers the measured number.
By their numbers in this assay, from the lowest: compounds 3, 1 and 2 (each within the scatter of the next).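

Moving the methoxy group, with 3-methoxyphenyl in place of 4-methoxyphenyl, gives a 1.3-fold lower number from compound 2 to compound 3 (0.10 log units; within the scatter) in this assay, so this change on the ring shows no readable preference. Replacing 4-chloro-3-(trifluoromethyl)phenyl with 3-methoxyphenyl gives a 1.3-fold lower number from compound 1 to compound 3 (0.10 log units; within the scatter), so the three aryl groups shown do not separate at this place.

As far as these compounds go, the effect of a nitrile or a carboxylic acid in place of the methoxy group stays open, as does that of a longer chain in the shared core. No evidence at hand bears on this result.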